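The source may hold more compounds than are shown below. What is called first, only, known or untested is meant among the compounds shown, and "the series" means these compounds.

Measured so far:
compound 1, `Cc1ccc2cc(CN(Cc3ccc(C(C)C)cc3)Cc3cccc(F)c3)c(=O)[nH]c2c1`: > 33000 nM
compound 2, `Cc1ccc2[nH]c(=O)c(CN(Cc3ccccc3)Cc3ccc(C(C)(C)C)cc3)cc2c1`: > 5000 nM

Both entries in a toxicity assay on MDCK cells (Canis lupus familiaris) for cytotoxicity, read by crystal violet staining, with a stated time of 48 h (a higher number here means that more compound is tolerated, a lower number that less compound is tolerated), are limits of the assay rather than numbers. For compound 1 the value > 33000 nM is a limit (the limit of > 33000 nM in this assay, at which 1 of the 2 values shown sits). For compound 2 the value > 5000 nM is likewise a limit (the limit of > 5000 nM in this assay, at which 1 of the 2 values shown sits). Going by the values given here, compound 2 therefore stands only at a limit in this assay, and the one further value shown is also a limit, so no step between measured compounds can be given and nothing about relative tolerance can be read from these two entries.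

Compound 3, `Cc1ccc2[nH]c(=O)c(CN(Cc3ccc(OCC(=O)O)cc3)Cc3ccc(C(C)(C)C)cc3)cc2c1`, is not yet measured in this assay. It differs from compound 2 in one place: carboxymethoxy in place of hydrogen on an aromatic carbon, para to a large group.

Without a measured step to rest on, a step that the limit leaves unreadable from compound 2 to compound 3 is expected, within the scatter and in no particular direction. For compound 3 the expected value in this assay is 20000 nM, with a range from 5000 nM to 80000 nM, most likely reported once more only as a limit.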

Compound 3, half-maximal cytotoxic concentration: > 10000 nM
Compound 3: no number, only a limit; the forecaster's own chance of this, stated with the estimate: 70%; the middle value lies beyond the limit too.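

No step can be read between compound 2 and compound 3 in this assay, as both entries are limits of the assay. Compound 3 gives > 10000 nM, which is a limit. The compounds shown leave open the actual tolerated concentration of each compound in this assay, and whether carboxymethoxy in place of hydrogen on an aromatic carbon shifts it at all.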